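The source may report more compounds than this note shows. Statements on the series, on what has been measured and on what is new or still open speak of the compounds shown alone.

Three compounds have been measured in a functional assay on TM4 cells (Mus musculus) for cytotoxicity, read by MTT assay, with a stated time of 72 h; a lower number here means a stronger inhibitor, a higher number a weaker inhibitor:

compound 1 `Nc1nc(Nc2ccccc2)sc1C(=O)c1cccnc1`: 5500 nM
compound 2 `Nc1nc(Nc2ccccc2)sc1C(=O)c1ccc(F)cc1`: 14000 nM
compound 3 `Nc1nc(Nc2ccc(S(N)(=O)=O)cc2)sc1C(=O)c1ccccc1[N+](=O)[O-]`: 16000 nM

Compound 3 and compound 2 lie within the scatter of each other at the upper end of these numbers, while compound 1 holds a lower number, beyond the scatter from both. The next compound to be measured in this assay is compound 4 `COc1cccc(C(=O)c2sc(Nc3ccc(S(N)(=O)=O)cc3)nc2N)c1`. It keeps the rest of compound 3 and carries 3-methoxyphenyl in place of 2-nitrophenyl on a carbonyl carbon.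

Going by the values given here, only one measured step changes a group at this place, and it is modest: a 2.5-fold higher number from compound 1 to compound 2 (0.41 log units; beyond the scatter). That step swaps other groups, and its two compounds also differ from compound 3 elsewhere in the structure, so it offers only a rough guide to size. No measurement shows the effect of either group in this change. A step of about that modest size is therefore the most that is expected here, in either direction, and a step within the scatter is quite possible.

The expected step is a 1.3-fold lower number from compound 3 to compound 4 (0.12 log units; within the scatter). For compound 4 the estimated value is 12000 nM, with an expected range of 5000 nM to 30000 nM.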

Compound 4, half-maximal inhibitory concentration: 6400 nM
Compound 4: middle estimate off by 1.9-fold (0.27 log units), on the high side; the measured number falls inside the stated range.
By their numbers in this assay, from the lowest: compounds 1 and 4 (each within the scatter of the next); then compounds 2 and 3 (each within the scatter of the next).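

With the rest of compound 3 held fixed, the group on the carbonyl carbon clearly affects the number in this assay, with a 2.5-fold lower number from compound 3 to compound 4 (0.40 log units; beyond the scatter). This is a second modest step at this place, alongside a 2.5-fold higher number from compound 1 to compound 2 (0.41 log units; beyond the scatter), and it is the first measured on the core that carries the sulfonamide, so the place is shown to respond on both cores, though only modestly in each. Nothing available explains why 3-methoxyphenyl gives the lower number here.

The change removes 2-nitrophenyl and brings in 3-methoxyphenyl in a single move, so the compounds shown cannot say whether the step comes from losing the nitro group, from gaining the methoxy group, or from where each sits on the phenyl ring. As far as these compounds go, it also remains open how a plain phenyl, or a phenyl carrying an amine or a carboxylic acid, would behave on this carbonyl carbon with the rest of compound 4 unchanged, and whether any such group would give a step larger than these modest ones.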